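From a Benzyl to a Benzoyl on the Ring Nitrogen

The source may hold more compounds than are shown below. What is called first, only, known or untested is meant among the compounds shown, and "the series" means these compounds.

Measured so far in a physicochemical assay for solubility, with a stated time of 3 days, at pH 7 (on this read-out higher numbers stand for higher solubility and lower numbers for lower solubility), with these results:
- compound 1 `NC(=O)c1ccc2[nH]c(-c3ccc(OCCC4CCCCN4Cc4ccc(Cl)cc4)cc3)nc2c1` gives 115000 nM
- compound 2 `NC(=O)c1ccc2[nH]c(-c3ccc(OCCC4CCCCN4Cc4ccc(Cl)c(Cl)c4)cc3)nc2c1` gives 229000 nM

For the measured compounds named here, only two numbers exist so far, and compound 2 lies within the usual scatter of compound 1, so the pair counts as level. The next structure is compound 3 `NC(=O)c1ccc2[nH]c(-c3ccc(OCCC4CCCCN4C(=O)c4ccccc4)cc3)nc2c1`, and the change leading to it is benzoyl in place of 3,4-dichlorobenzyl on an amine nitrogen in a ring in all. In words, this is benzoyl in place of 3,4-dichlorobenzyl on an amine nitrogen in a ring.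

Going by the values given here, only one measured step bears on this change, and only loosely. That step, a 2.0-fold higher number from compound 1 to compound 2 (0.30 log units; within the scatter) for chloro in place of hydrogen on an aromatic carbon, stays within the scatter. Among the compounds with values here, it offers no sign of a large shift from a chloro change alone, but no measured step covers the new carbonyl. A lower number is therefore only a cautious expectation, and the range must stay wide. The expected shift is a 3.3-fold lower number from compound 2 to compound 3 (0.51 log units; beyond the scatter) (an uncertain estimate). Compound 3 is expected at 70000 nM (estimated range 12000 nM to 250000 nM).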

Compound 3, solubility: 18000 nM
Compound 3: the middle estimate sits 3.9-fold (0.59 log units) above what was measured, and the stated range covers the measured number.
By their numbers in this assay, from the lowest: compound 3; then compounds 1 and 2 (each within the scatter of the next).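

In this assay, the ring nitrogen proves to be a place where swapping the group goes with a clear change in the number, which the chloro step alone gave no sign of. Benzoyl in place of 3,4-dichlorobenzyl gives a large drop (a 13-fold lower number from compound 2 to compound 3 (1.10 log units; beyond the scatter)), and benzoyl in place of 4-chlorobenzyl gives a modest one (a 6.4-fold lower number from compound 1 to compound 3 (0.81 log units; beyond the scatter)); both lie beyond the scatter and point the same way, and none of the three compounds goes against this. Nothing measured here gives a reason for the drop.

Each of these steps changes two things at once: the carbon joined to the ring nitrogen gains a carbonyl, and the chlorine on the aromatic ring is lost, so the steps cannot say which of the two goes with the lower number. A plain benzyl or a 4-chlorobenzoyl on the same nitrogen would pull these two apart, as each differs from a compound shown here in only one of them.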